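A Second Chloro on the Shared Core

A few compounds are considered here, and "the series" means these few. Any claim that something is new, unique, unknown or untested is made for them only; others in the source may bear on it.

Of the compounds shown here, two have been measured. Compound 1 `ClCc1ccccc1Cn1cnc2c(Cl)ncnc21` gives 2630 nM in a functional assay on UO-31 cells (Homo sapiens) for cytotoxicity, read by sulforhodamine B assay, with a stated time of 48 h; a lower number here means a stronger inhibitor of growth, a higher number a weaker inhibitor of growth. Compound 2 `ClCc1cccc(Cn2cnc3c(Cl)ncnc32)c1` differs from compound 1 only in where one group is placed, and compound 2 gives 1440 nM in this assay. Among the two numbers known, compound 2 holds the lower one, but the gap to compound 1 lies within the scatter of the measurement, so the two compounds cannot be ranked against each other on these data.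

The next compound, compound 3 `ClCc1cccc(Cn2cnc3c(Cl)nc(Cl)nc32)c1`, keeps everything found in compound 2 and carries one change: chloro in place of hydrogen on an aromatic carbon. Going by the values given here, no pair of measured compounds differs by a change of this kind, so nothing in the data so far tells how it will read out. Among the compounds with values here, with no precedent, the expectation for compound 3 in this assay is a step of about a 1.4-fold lower number from compound 2 to compound 3 (0.16 log units; within the scatter), that is, a number close to that of compound 2 with a slight lean toward stronger inhibition, and well inside a broad band of doubt. Compound 3 is therefore estimated at 1000 nM, with a range from 300 nM to 3500 nM.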

Compound 3, concentration for 50% growth inhibition: 1580 nM
Compound 3: the middle estimate sits 1.6-fold (0.20 log units) below what was measured; the range from low to high includes it.
By their numbers in this assay, from the lowest: compounds 2, 3 and 1 (each within the scatter of the next).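

Chloro in place of hydrogen on an aromatic carbon of the six-membered aromatic ring with 2 nitrogen, between two ring nitrogen atoms, gives a 1.1-fold higher number from compound 2 to compound 3 (0.04 log units; within the scatter) in this assay. Going by these compounds alone, this is the first reading of any substitution at this position, and it shows that a single chlorine atom can enter here with no step that stands clear of the scatter. On these data, compound 2 and compound 3 cannot be told apart, and the change neither helps nor harms growth inhibition in any way that can be read; no supporting measurement accounts for this outcome or ties it to any property of the chloro group.

On these data alone, whether an amine, a methoxy group or a longer chain on the same aromatic carbon would also leave the number within the scatter of compound 2 remains open, as one chloro group cannot speak for other groups at this position. Also open, as far as these compounds go, is whether chloro at this position would read the same on compound 1, where one group is placed differently.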